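Acyl sulfonamide series: carbamate replacing the cyclopropyl amide

The compounds below may be only part of what the source reports. "The series", "measured", "known", "first", "only" and "open" are said of these compounds alone.

Compound 1 `CC(C)C(=O)NCCS(=O)(=O)NC(=O)c1ccc(Nc2nc(NC3(c4ccc(Cl)cc4)CC3)nc(OCC(F)(F)F)n2)cc1` gives 84% in an ADME assay on microsomes from liver (Rattus norvegicus) for metabolic stability, with a stated time of 10 min; on this read-out higher numbers stand for a more stable compound and lower numbers for a less stable compound.
Compound 2 `CCS(=O)(=O)NC(=O)c1ccc(Nc2nc(NC3(c4ccc(Cl)cc4)CC3)nc(OCC(F)(F)F)n2)cc1` gives 85% in this assay.
Compound 3 `O=C(NS(=O)(=O)CCNC(=O)C1CC1)c1ccc(Nc2nc(NC3(c4ccc(Cl)cc4)CC3)nc(OCC(F)(F)F)n2)cc1` gives "not active" (no number reported) in this assay, so it has no single number there.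
Compound 4 `CC(C)OC(=O)NCCS(=O)(=O)NC(=O)c1ccc(Nc2nc(NC3(c4ccc(Cl)cc4)CC3)nc(OCC(F)(F)F)n2)cc1` is not yet measured.

Compound 3 stands without a number in this assay, so it gives no anchor of its own. The change to compound 4 is isopropoxy in place of cyclopropyl on a carbonyl carbon. For the measured compounds named here, the one measured step touching this region is a number 1 percentage points higher from compound 1 to compound 2 (within the scatter), where the whole acylamino group on the chain is removed without any shift beyond the scatter. Compound 1, carrying an isopropylcarbonyl on that nitrogen, is the closest relative of the isopropoxycarbonyl in compound 4. Compound 4 is therefore expected near 82%, with a range from 68% to 92% in this assay.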

Compound 4, percent of the compound remaining: 73%
Estimate against measurement, compound 4: 9 percentage points above; the measured number falls inside the stated range.
By their numbers in this assay, from the lowest: compound 4; then compounds 1 and 2 (each within the scatter of the next).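

In this assay, the chain position is no longer indifferent to its substituent: (isopropoxycarbonyl)amino in place of hydrogen gives a number 12 percentage points lower from compound 2 to compound 4 (beyond the scatter), whereas the isobutyramide of compound 1 had stayed within the scatter of compound 2. For the compounds shown here, the single change of isopropoxy in place of isopropyl on the carbonyl carbon gives a number 11 percentage points lower from compound 1 to compound 4 (beyond the scatter), so the oxygen-linked group separates from its closest carbon analogue. The step from compound 3 cannot be read, as compound 3 has no number.

Open, on these data alone, is whether a methoxy, a tert-butoxy or a dimethylamino group on that carbonyl carbon would read with compound 1 or with compound 4. Nothing available accounts for the lower number of compound 4.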